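Swapping benzyloxy for chloro on an aromatic carbon

The compounds below may be only part of what the source reports. "The series", "measured", "known", "first", "only" and "open" are said of these compounds alone.

Compound 1 `CCCCOc1cccc(-c2[nH]c3cc(OC)ccc3c(=O)c2C(=O)OCC)c1` reads > 22000 nM as a limit
Compound 2 `CCOC(=O)c1c(-c2cccc(OCc3ccccc3)c2)[nH]c2cc(OC)ccc2c1=O` reads > 22000 nM as a limit

In an ADME assay on HEK293 cells (Homo sapiens) for cytotoxicity, read by luminescence, with a stated time of 72 h (a higher number here means that more compound is needed for the effect, a lower number that less compound is needed), compound 2 reads > 22000 nM as a limit. The record so far is the limit of > 22000 nM in this assay, at which 2 of the 2 values shown sit, and holds no exact number. Compound 3 `CCOC(=O)c1c(-c2cccc(Cl)c2)[nH]c2cc(OC)ccc2c1=O` carries chloro in place of benzyloxy on an aromatic carbon, meta to a large group: chloro in place of benzyloxy on an aromatic carbon. Going by the values given here, the only measured step is a step that the two limits leave unreadable from compound 1 to compound 2 and it offers no size to carry over. The step expected here is a step that the limit leaves unreadable from compound 2 to compound 3 with no clear direction foreseen. Compound 3 is estimated at 30000 nM and expected to fall from 13000 nM to 60000 nM if a number is reported at all.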

Compound 3, half-maximal effective concentration: > 22000 nM
Compound 3 was reported as a limit; the forecaster's own chance of this, stated with the estimate: 85%; the middle value does not contradict the limit.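

Going by these compounds alone, no step among compound 1, compound 2 and compound 3 can be read, each result being a limit and not a number: the limit of > 22000 nM in this assay, at which 3 of the 3 values shown sit. The compounds shown leave open whether butoxy, benzyloxy and chloro differ at all in how much compound is needed for the effect.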